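Removing the methyl from the sulfonyl aryl of compound 2

This account rests on a few compounds, and the source may have more. Where it says the series, first, only, none or still open, it means among the compounds named here.

Measured compounds:
- compound 1, `CC(=O)c1ccc(NC(=O)C(C(C)C)N(C(=O)c2ccccc2)S(=O)(=O)c2ccc(C)cc2)cc1`: 29.7%
- compound 2, `CC(=O)c1ccc(NC(=O)C2CC(O)CN2S(=O)(=O)c2ccc(C)cc2)cc1`: 12.7%
- compound 3, `CCC(C)C(C(=O)Nc1ccc(C(C)=O)cc1)N(C(=O)c1ccccc1)S(=O)(=O)c1ccccc1`: 14.3%

Of the compounds shown here, three have been tested in a functional assay for inhibition, read by spectrophotometry, with a stated time of 20 min, tested at 3 mg/mL; on this read-out higher numbers stand for a stronger effect at the one concentration tested and lower numbers for a weaker effect. Compound 1 gives 29.7%, the highest number of the three. Compound 2 gives 12.7%, the lowest number shown; its gap to compound 3, which gives 14.3%, lies within the scatter, so these two cannot be ordered, while the gap from compound 2 to compound 1 lies beyond the scatter.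

Compound 4, `CC(=O)c1ccc(NC(=O)C2CC(O)CN2S(=O)(=O)c2ccccc2)cc1`, has not yet been measured in this assay. It differs from compound 2 in one place: hydrogen in place of methyl on an aromatic carbon. For the measured compounds named here, no pair of measured compounds shows this change, so there is no step from which its size can be read. Going by the values given here, the change is small, a single carbon, and nothing among the measured compounds speaks for a move in either direction. Compound 2 sits near the bottom of the range seen, which leaves little room for a fall and no basis for a rise.

The account therefore expects a step from compound 2 to compound 4 of a number 0.7 percentage points lower from compound 2 to compound 4 (within the scatter), that is, none beyond the scatter. Compound 4 is estimated at 12%, with a range from 3% to 22%.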

Compound 4, a percentage reported as inhibition, at one concentration (the size of the read-out at that concentration, not a potency): 49.8%
Compound 4: the middle estimate sits 37.8 percentage points below what was measured, and the stated range ends below it.
By their numbers in this assay, from the lowest: compounds 2 and 3 (each within the scatter of the next); then compound 1; then compound 4.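

The position is not a silent one: in this assay the change from 4-methylphenyl to phenyl, on an aromatic carbon para to a large group, gives a number 37.1 percentage points higher from compound 2 to compound 4 (beyond the scatter) in a single move. For the compounds shown here, the earlier compounds held no pair differing in this one place, so only this step shows that the loss of one carbon here can move the read-out well past the usual scatter, and it speaks for this one pair alone. Nothing among the data shown bears on why removing the methyl has this effect.

The compounds shown leave open whether the step depends on the rest of the molecule, for instance whether the same change would repeat itself on compound 1, which also carries 4-methylphenyl but differs from compound 4 in more than one place. They also leave open whether other groups in this place, such as a fluorine, a methoxy group, an amine or a carboxylic acid, would keep the higher number of compound 4 or return towards that of compound 2.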